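The source may hold more compounds than are shown below. What is called first, only, known or untested is meant among the compounds shown, and "the series" means these compounds.

Compound 3 `ClCc1ccc(Cn2cnc3c(Cl)nc(Cl)nc32)cc1` and compound 2 `ClCc1cccc(Cn2cnc3c(Cl)nc(Cl)nc32)c1` are built from the same atoms joined differently; the difference between the two cores is not broken down here. In a functional assay on OVCAR-3 cells (Homo sapiens) for cytotoxicity, read by sulforhodamine B assay, with a stated time of 48 h (on this read-out higher numbers stand for weaker inhibition of growth and lower numbers for stronger inhibition of growth), compound 3 gives 4370 nM, and compound 2 gives 3230 nM. Compound 1 `Nc1nc(Cl)c2ncn(Cc3ccc(CCl)cc3)c2n1` arises from compound 3 by a single change, (amino in place of chloro on an aromatic carbon), and in this assay compound 1 gives 5500 nM; the resulting step, a 1.3-fold higher number from compound 3 to compound 1 (0.10 log units; within the scatter), is small. Compound 4 `Nc1nc(Cl)c2ncn(Cc3cccc(CCl)c3)c2n1` has not yet been measured; it arises from compound 2 by the same change, (amino in place of chloro on an aromatic carbon), at a place described in identical words. Because the earlier step of a 1.3-fold higher number from compound 3 to compound 1 (0.10 log units; within the scatter) stayed within the scatter, the step from compound 2 to compound 4 in this assay is expected to be of similar size, a 1.3-fold higher number from compound 2 to compound 4 (0.11 log units; within the scatter). Compound 4 is therefore estimated to give about 4200 nM, most likely between 2500 nM and 7500 nM.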

Compound 4, concentration for total growth inhibition: 2290 nM
Compound 4: middle estimate off by 1.8-fold (0.26 log units), on the high side; measured number below the stated range.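

In this assay, amino in place of chloro on an aromatic carbon gives a 1.4-fold lower number from compound 2 to compound 4 (0.15 log units; within the scatter), and the two steps for this change do not differ beyond what repeated measurements allow: the same change on two cores in this assay, a 1.3-fold higher number (0.10 log units; within the scatter) from compound 3 to compound 1 and a 1.4-fold lower number (0.15 log units; within the scatter) from compound 2 to compound 4, 1.8-fold (0.25 log units) apart, within the scatter of two such steps. On these two cores, then, the change leaves the number within the scatter, and carrying it from one core to the other brings no difference that can be read. This does not show that the change is without effect on other cores or in other assays, and two steps this small fix no direction for it. The compounds shown leave open how a methoxy group or a dimethylamino group at the same place would read in this assay.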